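Cytotoxicity notes: from compound 3 to compound 4

A few compounds are considered here, and "the series" means these few. Any claim that something is new, unique, unknown or untested is made for them only; others in the source may bear on it.

Values so far in an ADME assay on L6 cells (Rattus norvegicus) for cytotoxicity, read by resazurin assay, with a stated time of 70 h (a higher number here means a weaker inhibitor, a lower number a stronger inhibitor), are as follows
- compound 1 `COc1cc(NC(C)CCCNC(=O)NC2CCCC2)c2ncccc2c1` gives "not determined" (no result reported) as its entry
- compound 2 `COc1cc(NC(C)CCCNC(=O)NNC(=O)/C(C)=C/c2ccccc2)c2ncccc2c1` gives 36500 nM as its entry
- compound 3 `COc1cc(NC(C)CCCNC(=O)NNC(=O)NCCCCCO)c2ncccc2c1` gives "not determined" (no result reported) as its entry

Among the measured compounds shown here, only one compound in this small set carries a number. Compound 3 stands at "not determined" (no result reported) in this assay and so offers no measured starting point, and compound 1 shares that position. Compound 4 `COc1cc(NC(C)CCCNC(=O)NNC(=O)N(CCO)CCO)c2ncccc2c1` has not yet been measured.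

The structural change is bis(2-hydroxyethyl)amino in place of (5-hydroxypentyl)amino on a carbonyl carbon and it puts bis(2-hydroxyethyl)amino in place of (5-hydroxypentyl)amino on a carbonyl carbon. The rest of the molecule stays the same. For the measured compounds named here, no measured pair shows what a change of this kind does, so any expectation here is weakly supported. No step beyond the usual scatter is expected between these two compounds in this assay, and no direction is favoured.

Going by the values given here, the only anchor is compound 2 at 36500 nM in the same test, and the range is kept wide for that reason. For compound 4 the expected value is 50000 nM with an estimated range from 18000 nM to 140000 nM as the working figures.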

Compound 4, half-maximal inhibitory concentration: 178000 nM
For compound 4 the middle estimate is 3.6-fold (0.55 log units) below the measured one; the measured number lies above the stated range.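

In this assay the series now has its first readable step at this carbonyl carbon, whose other neighbour is an amide-type nitrogen: a 4.9-fold higher number from compound 2 to compound 4 (0.69 log units; beyond the scatter), with bis(2-hydroxyethyl)amino in place of 1-methyl-2-phenylethenyl and the rest of the molecule unchanged. This shows that the group on this carbonyl carbon alone can move the number beyond the scatter, and the move here is towards weaker inhibition, with compound 4 at 178000 nM against compound 2 at 36500 nM. The steps to compound 1 and compound 3 cannot be read, so the direct exchange of (5-hydroxypentyl)amino for bis(2-hydroxyethyl)amino remains without a measured size, and nothing on hand accounts for the step that can be read.

Among the compounds shown here, with only this one step, it remains open whether the higher number follows the loss of 1-methyl-2-phenylethenyl or the entry of bis(2-hydroxyethyl)amino. The compounds shown also leave open how this assay responds to a carboxylic acid, a primary amine or a longer chain ending in hydroxyl on the same carbonyl carbon.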